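A few compounds are considered here, and "the series" means these few. Any claim that something is new, unique, unknown or untested is made for them only; others in the source may bear on it.

The series rests on a shared core, `CC1=CC[C@H](C(C)(C)N=C=S)CC1`, compound 1, for which a functional assay on UACC-62 cells (Homo sapiens) for inhibition, read by sulforhodamine B assay, with a stated time of 48 h (on this read-out lower numbers stand for stronger inhibition of growth and higher numbers for weaker inhibition of growth), gives "not determined" (no result reported). Compound 2, `CC1=CC[C@H](C(C)(C)NC(=S)N/N=C/c2ccccc2)CC1`, gives 31600 nM in this assay. Compound 3, `CC1=CC[C@H](C(C)(C)NC(=S)N/N=C/c2ccc(Cl)cc2)CC1`, gives 11200 nM in this assay. Among the compounds with values here, on these two numbers compound 2 stands highest; the only step measured so far, a 2.8-fold lower number from compound 2 to compound 3 (0.45 log units; beyond the scatter), is a modest one and came from chloro in place of hydrogen on an aromatic carbon. Compound 4, `CC1=CC[C@H](C(C)(C)NC(=S)N/N=C/c2ccc[nH]2)CC1`, differs from compound 2 in another way: 1H-pyrrol-2-yl in place of phenyl on a carbon with a double bond to nitrogen. Within the data shown here, no measured step swaps one aromatic ring for another, so the step from compound 2 to compound 3 bears on it only indirectly, showing that a change on an aromatic carbon moved this read-out by a modest amount. For compound 4 a step within the scatter, in no firm direction, is therefore expected, a 1.1-fold lower number from compound 2 to compound 4 (0.02 log units; within the scatter). The estimate for compound 4 in this assay is 30000 nM, with a range from 10000 nM to 90000 nM.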

Compound 4, concentration for 50% growth inhibition: 14800 nM
Compound 4: middle estimate off by 2.0-fold (0.31 log units), on the high side; the measured number falls inside the stated range.
By their numbers in this assay, from the lowest: compounds 3 and 4 (each within the scatter of the next); then compound 2.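

At the carbon with a double bond to nitrogen, the aromatic ring itself can be exchanged with an effect on the read-out. In this assay the change from phenyl to 1H-pyrrol-2-yl gives a 2.1-fold lower number from compound 2 to compound 4 (0.33 log units; beyond the scatter) and lies beyond the scatter, whereas the earlier compounds had shown only a chloro change on the phenyl ring. The change from 4-chlorophenyl to 1H-pyrrol-2-yl gives a 1.3-fold higher number from compound 3 to compound 4 (0.12 log units; within the scatter) and lies within the scatter, so these two rings cannot be told apart here, and nothing at hand explains either step.

The compounds shown leave open whether the hydrogen on the ring nitrogen of 1H-pyrrol-2-yl matters, a question that furan-2-yl or 1-methylpyrrol-2-yl would address. They also leave open whether chloro on the 1H-pyrrol-2-yl ring would lower the number further.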